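The compounds below may be only part of what the source reports. "The series", "measured", "known", "first", "only" and "open" are said of these compounds alone.

Compound 1 `C=C[C@@](C)(/C=C/c1ccc(Nc2ccc(OC)cc2)cc1)CCC=C(C)C`, compound 2 `C=C[C@@](C)(/C=C/c1ccc(Nc2ccc(OC)c(F)c2)cc1)CCC=C(C)C` and compound 3 `C=C[C@@](C)(/C=C/c1ccc(Nc2ccc(F)c(F)c2)cc1)CCC=C(C)C` share one core and differ only in the aromatic ring carried on the nitrogen. All three were tested in a functional assay on Raji cells (Homo sapiens) for cytotoxicity, with a stated time of 72 h; on this read-out lower numbers stand for an effect already at smaller amounts and higher numbers for an effect only at larger amounts of compound. Compound 1 gives > 26000 nM, a limit and not a number. Compound 2 gives > 26000 nM, again a limit. Compound 3 gives > 26000 nM, also a limit. Compound 3 therefore offers no exact starting value, and the three compounds share (the limit of > 26000 nM in this assay, at which 3 of the 3 values shown sit).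

Compound 4 `C=C[C@@](C)(/C=C/c1ccc(Nc2cc(F)c(F)c(F)c2)cc1)CCC=C(C)C` comes from compound 3 through one change: fluoro in place of hydrogen on an aromatic carbon. Here 3,4-difluorophenyl becomes 3,4,5-trifluorophenyl. The nearest measured case is the same kind of swap, a step that the two limits leave unreadable from compound 1 to compound 2. The other two measured steps are a step that the two limits leave unreadable from compound 1 to compound 3 and a step that the two limits leave unreadable from compound 2 to compound 3. None of these gives a size, so no step beyond the scatter is expected in this assay, in either direction. The expected step is a step that the limit leaves unreadable from compound 3 to compound 4. The estimate for compound 4 is 30000 nM, within an estimated range of 12000 nM to 60000 nM.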

Compound 4, half-maximal effective concentration: > 26000 nM
Compound 4 gave a limit, no number (the forecaster's own chance of this, stated with the estimate: 85%); the middle value does not contradict the limit.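

No step to compound 4 can be read from compound 1, compound 2 or compound 3, since all four compounds give only a limit and no number: the limit of > 26000 nM in this assay, at which 4 of the 4 values shown sit.

The compounds shown leave open whether changing the aromatic ring on the nitrogen shifts the result in this assay at all.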